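Removing the hydroxymethyl group from the ring carbon

A few compounds are considered here, and "the series" means these few. Any claim that something is new, unique, unknown or untested is made for them only; others in the source may bear on it.

Among the compounds with values here, in a functional assay on MCF7 cells (Homo sapiens) for cytotoxicity, read by MTT assay, with a stated time of 72 h (a lower number here means a stronger inhibitor, a higher number a weaker inhibitor), compound 1 `CC1(C)OCC(Cn2cc(Cn3c4c(c5ccccc53)C(=O)c3c[n+]([O-])c5ccccc5c3C4=O)nn2)O1` gives 290 nM and compound 2 `CC1(C)O[C@@H](CO)[C@H](Cn2cc(Cn3c4c(c5ccccc53)C(=O)c3c[n+]([O-])c5ccccc5c3C4=O)nn2)O1` gives 690 nM, the higher of the two numbers so far. Within the data shown here, the one measured step is a 2.4-fold higher number from compound 1 to compound 2 (0.38 log units; beyond the scatter), where 5-(hydroxymethyl)-2,2-dimethyl-1,3-dioxolan-4-yl stands in place of 2,2-dimethyl-1,3-dioxolan-4-yl.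

Compound 3 `CC1(C)OC[C@H](Cn2cc(Cn3c4c(c5ccccc53)C(=O)c3c[n+]([O-])c5ccccc5c3C4=O)nn2)O1` reverses that group change, with hydrogen in place of hydroxymethyl on a saturated ring carbon. It carries the 2,2-dimethyl-1,3-dioxolan-4-yl group of compound 1, but with the configuration at the ring carbon defined, whereas compound 1 has none drawn there. Among the measured compounds shown here, no measured pair isolates the effect of that configuration, so it adds uncertainty in both directions.

For the measured compounds named here, the expectation rests on the single step of a 2.4-fold higher number from compound 1 to compound 2 (0.38 log units; beyond the scatter), read backwards, and on compound 1 at 290 nM. A step of similar size toward a lower number is therefore expected in this assay. The estimated step is a 2.3-fold lower number from compound 2 to compound 3 (0.36 log units; beyond the scatter). For compound 3 the expected value is 300 nM, with an estimated range of 130 nM to 650 nM.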

Compound 3, half-maximal inhibitory concentration: 530 nM
Compound 3: middle estimate off by 1.8-fold (0.25 log units), on the low side; the measured number falls inside the stated range.
By their numbers in this assay, from the lowest: compounds 1, 3 and 2 (each within the scatter of the next, the first and the last beyond it).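

In this assay, hydrogen in place of hydroxymethyl on a saturated ring carbon gives a 1.3-fold lower number from compound 2 to compound 3 (0.11 log units; within the scatter), so with a configuration drawn at the ring carbon, this group exchange does not stand out from the scatter. The other new comparison keeps the atoms and bonds the same and gives a 1.8-fold higher number from compound 1 to compound 3 (0.26 log units; within the scatter), which also stays inside the scatter and places compound 3 within reach of both earlier compounds. The one step beyond the scatter remains a 2.4-fold higher number from compound 1 to compound 2 (0.38 log units; beyond the scatter), and it can no longer be read as a clean effect of hydroxymethyl, because compound 3, the defined counterpart of compound 1, differs from it in one respect: the fact that one of compounds 1 and 3 is drawn with a defined configuration and the other without, at the place where they differ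

The series therefore leaves open whether hydroxymethyl on this ring carbon matters at all in this cytotoxicity read-out, and how the opposite configuration at the ring carbon of compound 3 would compare. It also leaves open whether an aminomethyl group, a carboxylic acid or a longer chain on the same saturated ring carbon would move the number beyond the scatter.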